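Swapping chloro for nitro on the aryl ketone of compound 1

The source may report more compounds than this note shows. Statements on the series, on what has been measured and on what is new or still open speak of the compounds shown alone.

Measured so far:
compound 1, `CCOC(=O)c1[nH]c(=O)c(C#N)cc1C(=O)c1ccc(Cl)cc1`: 218000 nM
compound 2, `O=C(c1ccc([N+](=O)[O-])cc1)c1cc(C(=O)O)c(=O)[nH]c1C(=O)O`: 439000 nM

Of the compounds shown here, two have been tested in an ADME assay on L929 cells (Mus musculus) for cytotoxicity, read by MTT assay, with a stated time of 72 h; a lower number here means that less compound is tolerated, a higher number that more compound is tolerated. Compound 1 `CCOC(=O)c1[nH]c(=O)c(C#N)cc1C(=O)c1ccc(Cl)cc1` gives 218000 nM in this assay. Compound 2 `O=C(c1ccc([N+](=O)[O-])cc1)c1cc(C(=O)O)c(=O)[nH]c1C(=O)O` gives 439000 nM in this assay. On these two numbers compound 1 stands together with compound 2, the gap between them lying within the usual scatter of such measurements, so the two are not told apart here. Compound 2 differs from compound 1 in several places at once, so no single step can be read from this pair.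

The compound now in question is compound 3 `CCOC(=O)c1[nH]c(=O)c(C#N)cc1C(=O)c1ccc([N+](=O)[O-])cc1`. It differs from compound 1 in one place: nitro in place of chloro on an aromatic carbon. Because compound 1 gives 218000 nM and compound 2, which also carries a nitro group, gives 439000 nM, the two numbers in hand sit close to each other, and the exchange is expected to move this assay little, if at all, beyond the scatter. The step from compound 1 to compound 3 is expected to be a 1.2-fold higher number from compound 1 to compound 3 (0.08 log units; within the scatter), with no clear direction. Compound 3 is therefore estimated at 260000 nM in this assay, within a range from 110000 nM to 620000 nM.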

Compound 3, half-maximal cytotoxic concentration: 213000 nM
Compound 3: the middle estimate sits 1.2-fold (0.09 log units) above what was measured, within the range that was stated.
By their numbers in this assay, from the lowest: compounds 3, 1 and 2 (each within the scatter of the next, the first and the last beyond it).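

For the compounds shown here, with the rest of the core of compound 1 held fixed, nitro in place of chloro on this aromatic carbon, para to a large group, gives the first step in this assay that can be read on its own (a 1.0-fold lower number from compound 1 to compound 3 (0.01 log units; within the scatter)), and that step lies within the scatter. In this one pair, the move from a single chlorine to a nitro group of three heavy atoms, with its two hydrogen-bond acceptors, therefore leaves the read-out unchanged within the scatter, so compound 1 and compound 3 are not told apart here. The compounds shown offer no measurement that could account for this result.

Going by these compounds, whether this holds for other groups at the same aromatic carbon stays open, for an amine or a methoxy group, for instance, since only chloro and nitro appear there. Compound 2 differs from compound 3 in more than one place, so no step can be read for the ethyl ester or the nitrile, and replacing either with a carboxylic acid alone remains an open question.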